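From trifluoromethyl to difluoromethyl at the solubility limit

The compounds below may be only part of what the source reports. "The series", "measured", "known", "first", "only" and "open" are said of these compounds alone.

In a physicochemical assay for solubility (a lower number here means a less soluble compound, a higher number a more soluble compound), compound 1 (`CS(=O)(=O)c1ccc(-n2nc(C(F)F)c(C#N)c2-c2cc(F)cc(F)c2)nc1`) gives 50 ug/mL as a measured number. Compound 2 (`C[C@@H]1CN(c2c(C#N)c(C(F)(F)F)nn2-c2ccc(S(C)(=O)=O)cn2)[C@H](C)CO1`) reads > 200 ug/mL in this assay and this is a limit, not a number. Compound 2 thus stands at the limit of > 200 ug/mL in this assay, at which 1 of the 2 values shown sits, and gives no exact reading to start from.

Compound 3 (`C[C@@H]1CN(c2c(C#N)c(C(F)F)nn2-c2ccc(S(C)(=O)=O)cn2)[C@H](C)CO1`) differs from compound 2 in one place, by hydrogen in place of fluoro on a saturated chain carbon bound to an aromatic carbon and two fluorine atoms. The same difference reads trifluoromethyl to difluoromethyl. Within the data shown here, no measured pair shows this change on its own. The expected change is none beyond the scatter, in either direction, and the estimated step is a step that the limit leaves unreadable from compound 2 to compound 3 in this assay as things stand. Compound 3 is expected to give about 220 ug/mL in this assay with an estimated range from 100 ug/mL to 400 ug/mL and a fair chance of another limit.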

Compound 3, solubility: > 200 ug/mL
Compound 3: only a limit was reported; the forecaster's own chance of this, stated with the estimate: 65%; the middle value does not contradict the limit.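

In this assay compound 3 gives > 200 ug/mL, which is a limit of the assay and not a number. With difluoromethyl on both sides, a non-aromatic ring group in place of an aromatic ring of carbon only, on an aromatic carbon, gives an at least 4.0-fold higher number from compound 1 to compound 3 (0.60 log units; beyond the scatter), so this change is readable and lies beyond the scatter. The change from trifluoromethyl to difluoromethyl, by contrast, cannot be read, since neither side of it gives an exact number: the limit of > 200 ug/mL in this assay, at which 2 of the 3 values shown sit.

The compounds shown leave open what trifluoromethyl to difluoromethyl does in a compound that reads short of the limit. They also leave open whether a plain methyl group in place of difluoromethyl, or a simple amine in place of the non-aromatic ring group, would still reach that limit.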